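Replacing a Piperazine Ring with a Dimethylamino Group

The source may report more compounds than this note shows. Statements on the series, on what has been measured and on what is new or still open speak of the compounds shown alone.

Compound 1, `CC(C)COc1ccc(CN(CC(=O)NCc2ccccc2Cl)S(=O)(=O)c2ccc(CN3CCN(C)CC3)cc2)cc1`: 113 nM
Compound 2, `COc1cc(CN(CC(=O)NCc2ccccc2Cl)S(=O)(=O)c2ccc(CN3CCCCC3)cc2)ccc1OCC(C)C`: 34 nM
Compound 3, `COc1cc(CN(CC(=O)NCc2ccccc2Cl)S(=O)(=O)c2ccc(CN3CCN(C)CC3)cc2)ccc1OCC(C)C`: 11 nM

In an assay on WI 38 cells for displacement of a labelled ligand from B1 bradykinin receptor (Homo sapiens) (on this read-out higher numbers stand for weaker inhibition and lower numbers for stronger inhibition), compound 3 gives 11 nM, the lowest of the three numbers. The nearest is compound 2, which gives 34 nM; the step of a 3.1-fold lower number from compound 2 to compound 3 (0.49 log units; beyond the scatter) is modest but beyond the scatter. Compound 1 gives 113 nM, and the step of a 10-fold lower number from compound 1 to compound 3 (1.01 log units; beyond the scatter) is large.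

Compound 4, `COc1cc(CN(CC(=O)NCc2ccccc2Cl)S(=O)(=O)c2ccc(CN(C)C)cc2)ccc1OCC(C)C`, differs from compound 3 in one place: dimethylamino in place of 4-methylpiperazin-1-yl on a saturated chain carbon bound to an aromatic carbon. For the measured compounds named here, the only measured step at this position is a 3.1-fold lower number from compound 2 to compound 3 (0.49 log units; beyond the scatter), in which one six-membered ring replaced another and the number fell modestly. Going by the values given here, no measured step removes the ring altogether, so there is no direct guide for this change, and a step in either direction of modest size is possible. Since the ring that gave the lowest number is lost, a somewhat higher number is expected, and the expected step is a 2.3-fold higher number from compound 3 to compound 4 (0.36 log units; beyond the scatter). Compound 4 is estimated at 25 nM, within a range from 8 nM to 80 nM.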

Compound 4, inhibition constant: 93 nM
Compound 4: the middle estimate sits 3.7-fold (0.57 log units) below what was measured; measured number above the stated range.
By their numbers in this assay, from the lowest: compound 3; then compound 2; then compounds 4 and 1 (each within the scatter of the next).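

In this assay, this position responds more to losing the ring than to swapping one ring for another: dimethylamino in place of 4-methylpiperazin-1-yl gives an 8.5-fold higher number from compound 3 to compound 4 (0.93 log units; beyond the scatter), while dimethylamino in place of piperidin-1-yl gives a 2.7-fold higher number from compound 2 to compound 4 (0.44 log units; beyond the scatter). Among these three compounds, which differ only here, both six-membered rings give lower numbers than the open dimethylamino group, and the ring with a second nitrogen gives the lowest. Nothing available explains these differences.

The compounds shown leave open whether the ring itself or its second nitrogen matters more. Morpholin-4-yl, with oxygen in that nitrogen's place, and an open (dimethylamino)ethylamino chain, which keeps both nitrogens without the ring, would help separate the two.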